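The source may report more compounds than this note shows. Statements on the series, on what has been measured and on what is new or still open speak of the compounds shown alone.

Measured compounds:
- compound 1, `Nc1nc(N)c2cc(CSC(=S)N3CCN(c4ccc(O)cc4)CC3)ccc2n1`: 5180 nM
- compound 2, `COc1ccc(N2CCN(C(=S)SCc3ccc4nc(N)nc(N)c4c3)CC2)cc1`: 1660 nM

In a functional assay on HeLa cells (Homo sapiens) for antiproliferative activity, read by MTT assay, with a stated time of 72 h (on this read-out higher numbers stand for weaker inhibition and lower numbers for stronger inhibition), compound 2 stands with the lowest of the two numbers; its nearest neighbour is compound 1, separated by a 3.1-fold lower number from compound 1 to compound 2 (0.49 log units; beyond the scatter), a modest step that lies beyond the scatter. Compound 3, `Nc1nc(N)c2cc(CSC(=S)N3CCN(c4ccccc4F)CC3)ccc2n1`, is not yet measured. It differs from compound 2 as follows: 2-fluorophenyl in place of 4-methoxyphenyl on an amine nitrogen in a ring. Within the data shown here, no measured step covers this exchange of one aryl group for another on the ring nitrogen; the only measured step, a 3.1-fold lower number from compound 1 to compound 2 (0.49 log units; beyond the scatter), touches the same aryl group but only at its oxygen, and it shows that a change there can move the number modestly. Compound 3 is therefore expected to give 3000 nM in this assay, with a range of 1200 nM to 8000 nM. That expectation means a step of a 1.8-fold higher number from compound 2 to compound 3 (0.26 log units; within the scatter), which may not rise beyond the scatter.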

Compound 3, half-maximal inhibitory concentration: 6660 nM
Beside the measured number, compound 3's estimate is 2.2-fold (0.35 log units) below it; the range from low to high includes it.
By their numbers in this assay, from the lowest: compound 2; then compounds 1 and 3 (each within the scatter of the next).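

Exchanging the whole aryl group on the ring nitrogen also moves the number in this assay: 2-fluorophenyl in place of 4-methoxyphenyl raises it (a 4.0-fold higher number from compound 2 to compound 3 (0.60 log units; beyond the scatter)), so the lower number of compound 2 does not hold across this exchange. 2-fluorophenyl in place of 4-hydroxyphenyl, by contrast, leaves the number within the scatter (a 1.3-fold higher number from compound 1 to compound 3 (0.11 log units; within the scatter)), and among these three aryl groups only 4-methoxyphenyl stands apart. Nothing measured here accounts for either step.

The compounds shown do not separate the arrival of the fluorine from the loss of the methoxy group in the step to compound 3. From the compounds shown here alone, it also stays open how a plain phenyl, a pyridine ring or a cyclohexyl group on the same ring nitrogen would read.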